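Methoxy for Fluoro on a Shared Amide Core

A few compounds are considered here, and "the series" means these few. Any claim that something is new, unique, unknown or untested is made for them only; others in the source may bear on it.

Three measured compounds share one core. Compound 1 `COc1ccccc1C(=O)NCc1ccc(CNS(=O)(=O)c2ccccc2)cc1` carries a methoxy group, compound 2 `O=C(NCc1ccc(CNS(=O)(=O)c2ccccc2)cc1)c1ccccc1F` carries a fluoro group in its place, and compound 3 `Cc1ccc(S(=O)(=O)NCc2ccc(CNC(=O)c3ccccc3F)cc2)cc1` keeps that fluoro group and adds a methyl group at the other end of the molecule. In an assay on MDA-MB-231 cells for binding affinity to C-X-C chemokine receptor type 4 (Homo sapiens), read by immunofluorescence and microscopy, with stated times of 10 min and 30 min (a higher number here means that more compound is needed for the effect, a lower number that less compound is needed), compound 1 gives 1 nM, compound 2 gives 1000 nM, and compound 3 gives 1000 nM. The change methoxy in place of fluoro on an aromatic carbon brings a 1000-fold lower number from compound 2 to compound 1 (3.00 log units; beyond the scatter). The change methyl in place of hydrogen on an aromatic carbon brings no change at the digits printed from compound 2 to compound 3 (within the scatter).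

Compound 4 `COc1ccccc1C(=O)NCc1ccc(CNS(=O)(=O)c2ccc(C)cc2)cc1` has not yet been measured. Going by the values given here, it differs from compound 3 by methoxy in place of fluoro on an aromatic carbon, which is the same change, at the same place, as the one that turns compound 2 into compound 1. Because that earlier step was a 1000-fold lower number from compound 2 to compound 1 (3.00 log units; beyond the scatter), a step of a 670-fold lower number from compound 3 to compound 4 (2.82 log units; beyond the scatter) is expected here, resting on that single precedent. Compound 4 is therefore estimated at 1.5 nM, expected to lie between 0.3 nM and 10 nM.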

Compound 4, effective concentration (reported as EC, without a stated level of effect): 100 nM
For compound 4 the middle estimate is 67-fold (1.82 log units) below the measured one, outside the stated range (above it).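

Methoxy in place of fluoro gives a lower number on both cores in this assay, but on the methyl-bearing core the result is a 10-fold lower number from compound 3 to compound 4 (1.00 log units; beyond the scatter), so the size of the step did not carry over: the same change on two cores in this assay, a 1000-fold lower number (3.00 log units; beyond the scatter) from compound 2 to compound 1 and a 10-fold lower number (1.00 log units; beyond the scatter) from compound 3 to compound 4, 100-fold (2.00 log units) apart, beyond the scatter of two such steps

The methyl group likewise depends on its core, with a 100-fold higher number from compound 1 to compound 4 (2.00 log units; beyond the scatter), although the fluoro pair shows no change: the same change on two cores in this assay, no change at the digits printed (within the scatter) from compound 2 to compound 3 and a 100-fold higher number (2.00 log units; beyond the scatter) from compound 1 to compound 4, 100-fold (2.00 log units) apart, beyond the scatter of two such steps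

These four compounds show that the two changes do not act independently here, but they do not show why, or how either change would behave on a further core.

Still open, on these data alone, is what an ethoxy group or a chlorine atom would do in place of methoxy. Also open, as far as these compounds go, is whether an amine or a carboxylic acid in place of the methyl group would follow the same pattern.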